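Removing one methoxy from compound 3's core

The source may report more compounds than this note shows. Statements on the series, on what has been measured and on what is new or still open speak of the compounds shown alone.

Working notes on a short series tested in an assay on HEK293-TREx cells for antagonist activity at transient receptor potential cation channel subfamily A member 1 (Homo sapiens), read by fluorescence and calcium flux, with a stated time of 72 h; a lower number here means a stronger inhibitor, a higher number a weaker inhibitor. Compound 1 `O=[N+]([O-])c1ccc(Oc2ncnc3[nH]ccc23)cc1` gives only a limit, > 32000 nM, which is the assay limit rather than a number (the limit of > 32000 nM in this assay, at which 1 of the 3 values shown sits). Compound 2 `COc1ccc2c(Oc3ccc(F)cc3F)ncnc2c1` gives 3000 nM. Compound 3 `COc1cc2ccnc(Oc3ccc(F)cc3F)c2cc1OC` gives 630 nM, the lowest of the two numbers in this assay; the gap to compound 2 is beyond the scatter. Compound 2 and compound 3 differ in more than one place, so no single step can be read from that pair.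

Compound 4 `COc1ccc2c(Oc3ccc(F)cc3F)nccc2c1` has not yet been measured in this assay. Relative to compound 3 the change is hydrogen in place of methoxy on an aromatic carbon. Among the measured compounds shown here, no measured step describes this removal alone. With only the two numbers and one limit to go on, the expectation is a modest weakening, a step from compound 3 to compound 4 of roughly a 2.5-fold higher number from compound 3 to compound 4 (0.40 log units; beyond the scatter), which is beyond the scatter but not by much. On that basis compound 4 is estimated at 1600 nM in this assay, with a plausible range from 500 nM to 5000 nM, to be checked against the measurement.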

Compound 4, half-maximal inhibitory concentration: 1300 nM
The estimate for compound 4 lay 1.2-fold (0.09 log units) above the measured number; the measured number falls inside the stated range.
By their numbers in this assay, from the lowest: compound 3; then compound 4; then compound 2. At a limit, above all of these: compound 1.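

In this assay, among the compounds shown here, the exchange of this methoxy for hydrogen gives a 2.1-fold higher number from compound 3 to compound 4 (0.31 log units; beyond the scatter) and is the first step that can be read at a single place, since the earlier numbered pair differs in more than one place. The step is modest but beyond the scatter, so this methoxy, on an aromatic carbon and ortho to a methoxy group, contributes measurably to the lower number of compound 3, yet it is not needed for activity in this assay: without it compound 4 still gives 1300 nM as a real number rather than a limit. Nothing in the data at hand gives a cause for the step.

As far as these compounds go, it remains open whether the other methoxy of compound 3 can be replaced by hydrogen at a similar price, and whether the same exchange gives a step of this size on the core of compound 2. Also open, from the compounds shown here alone, is whether an ethoxy, a chlorine or an amine on this aromatic carbon would give a lower or a higher number than the methoxy of compound 3, since only hydrogen has been read against it here.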